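The compounds below may be only part of what the source reports. "The series", "measured", "known", "first", "only" and "open" are said of these compounds alone.

Compound 1 `Cc1ccc(NC2=CC(=O)c3nc4n(c3C2=O)[C@H]2OC[C@@H](O)[C@H]2OC4)cc1` gives 1660 nM in a functional assay on MCF7 cells (Homo sapiens) for inhibition, read by sulforhodamine B assay; on this read-out higher numbers stand for weaker inhibition and lower numbers for stronger inhibition.
Compound 2 `CCCc1ccc(NC2=CC(=O)c3c(nc4n3[C@H]3OC[C@@H](O)[C@H]3OC4)C2=O)cc1` gives only the assay limit > 4000 nM in this assay.
Compound 3 `COc1ccccc1NC1=CC(=O)c2c(nc3n2[C@H]2OC[C@@H](O)[C@H]2OC3)C1=O` gives 6580 nM in this assay.

Compound 1 holds the lowest of the two numbers in this assay, with compound 3 higher by a margin beyond the scatter. The value of compound 2 is a limit of > 4000 nM in this assay, at which 1 of the 3 values shown sits, and not a number. Within the data shown here, the one measured step, a step that the limit leaves unreadable from compound 2 to compound 3, exchanges one aromatic amine for another and its size cannot be read because of the limit (the limit of > 4000 nM in this assay, at which 1 of the 3 values shown sits).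

Compound 4 `CCCN(CCC)C1=CC(=O)c2nc3n(c2C1=O)[C@H]1OC[C@@H](O)[C@H]1OC3` differs from compound 1 by dipropylamino in place of (4-methylphenyl)amino on a double-bonded ring carbon. Among the measured compounds shown here, no measured step bears on this change: the only step compares two aromatic amines and keeps the ring and the amine hydrogen in both. For the measured compounds named here, the aromatic ring and the donor are removed with no precedent among the measured compounds, so the expectation for compound 4 rests on the two aryl compounds standing weaker or at the limit. Compound 4 is expected to give 4000 nM, within 1000 nM to 16000 nM. The expected step of a 2.4-fold higher number from compound 1 to compound 4 (0.38 log units; beyond the scatter) is toward weaker inhibition, with wide uncertainty.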

Compound 4, half-maximal inhibitory concentration: > 16000 nM
Compound 4 gave a limit, no number (the forecaster's own chance of this, stated with the estimate: 40%); middle value at least 4.0-fold (0.60 log units) from the limit.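

Compound 4 gives no number in this assay, only a limit: the limit of > 16000 nM in this assay, at which 1 of the 4 values shown sits.

Even so, the change can be read in one direction: dipropylamino in place of (4-methylphenyl)amino on a double-bonded ring carbon gives an at least 9.6-fold higher number from compound 1 to compound 4 (0.98 log units; beyond the scatter), so this position is not indifferent to what the amine carries, and the change goes toward weaker inhibition. The aromatic ring and the hydrogen-bond donor leave in the same change, so this step cannot tell which of the two matters, or whether both do.

The compounds shown leave open whether propylamino, which keeps the amine hydrogen without the aromatic ring, would stand nearer to compound 1 or to compound 4. The same question holds for N-methyl-4-methylanilino, which keeps the aromatic ring without the amine hydrogen.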